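The compounds below may be only part of what the source reports. "The series", "measured", "known", "first", "only" and "open" are said of these compounds alone.

Measured in an ADME assay on MT4 cells (Homo sapiens) for cytotoxicity, read by MTT assay, with a stated time of 5 days; on this read-out lower numbers stand for higher toxicity in this test and higher numbers for lower toxicity in this test:
compound 1 `COc1cc2nc(SCC(=O)Nc3cccc(S(N)(=O)=O)c3)nc(Nc3c(Cl)cc(/C=C/C#N)cc3Cl)c2cc1OC`: > 194000 nM
compound 2 `COc1cc2nc([S+]([O-])CC(=O)Nc3cccc(Cl)c3)nc(Nc3c(Cl)cc(/C=C/C#N)cc3Cl)c2cc1OC`: 68900 nM
compound 3 `COc1cc2nc([S+]([O-])CC(=O)Nc3cccc(F)c3)nc(Nc3c(Cl)cc(/C=C/C#N)cc3Cl)c2cc1OC`: 9550 nM

Compound 1 has the entry > 194000 nM, which is a limit and not a number. Of the two true numbers, compound 3 holds the lower, 9550 nM, and compound 2 the higher, 68900 nM.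

Next comes compound 4 `COc1cc2nc([S+]([O-])CC(=O)Nc3ccccc3C#N)nc(Nc3c(Cl)cc(/C=C/C#N)cc3Cl)c2cc1OC`, with 2-cyanophenyl in place of 3-fluorophenyl on an amide-type nitrogen. Among the compounds with values here, only one measured step bears on this change: a 7.2-fold lower number from compound 2 to compound 3 (0.86 log units; beyond the scatter), with fluoro in place of chloro on an aromatic carbon. That step shows that a single substituent swap in this series can shift the number beyond the scatter. It is only a loose guide, since compound 4 exchanges the whole group and not just one halogen. A modest step of similar or smaller size is therefore expected, with the direction uncertain. Within the data shown here, a higher number is somewhat more likely, given that compound 3 at 9550 nM has the lowest number so far. The expected move is a 2.1-fold higher number from compound 3 to compound 4 (0.32 log units; beyond the scatter). For compound 4 the estimated value is 20000 nM, with an expected range from 5000 nM to 80000 nM.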

Compound 4, half-maximal cytotoxic concentration: > 206000 nM
Compound 4: only a limit was reported (the forecaster's own chance of this, stated with the estimate: 15%); middle value at least 10-fold (1.01 log units) away from the limit.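

In this assay, the group on the amide-type nitrogen moves the number much further than the halogen swap alone had shown: 2-cyanophenyl in place of 3-fluorophenyl gives an at least 21-fold higher number from compound 3 to compound 4 (1.33 log units; beyond the scatter). The same group in place of 3-chlorophenyl gives an at least 2.9-fold higher number from compound 2 to compound 4 (0.47 log units; beyond the scatter), so the higher number holds against both halogen-bearing partners, and this position can separate compounds in this series by a wide margin, though the size of each step is open-ended. Compound 4 carries a limit and not a number: the limit of > 206000 nM in this assay, at which 1 of the 4 values shown sits.

The compounds shown leave open whether the shift follows the nitrile itself, its place on the ring or the loss of the halogen, since 2-cyanophenyl differs from both 3-fluorophenyl and 3-chlorophenyl in more than one respect, and plain phenyl or 3-cyanophenyl on the same nitrogen would begin to separate these readings. Compound 1 differs from compound 4 both at the sulfur and on the aryl group, so it gives no reading of this change.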